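This account rests on a few compounds, and the source may have more. Where it says the series, first, only, none or still open, it means among the compounds named here.

Three compounds built on a shared core were examined in an ADME assay on MDBK cells (Bos taurus) for cytotoxicity; on this read-out lower numbers stand for higher toxicity in this test and higher numbers for lower toxicity in this test. Compound 1 `Clc1ccccc1Cn1ccc2nc(-c3ccccc3)nc-2c1` carries a 2-chlorophenyl on the saturated chain carbon bound to an aromatic nitrogen. In this assay compound 1 gives only a limit, > 100000 nM, and its true value is not known beyond that bound. Compound 2 `c1ccc(-c2ccc(Cn3ccc4nc(-c5ccccc5)nc-4c3)cc2)cc1` is measured in this assay at 18000 nM. Compound 3 `c1ccc(-c2nc3ccn(Cc4ccc5ccccc5c4)cc-3n2)cc1` gives in this assay 67000 nM. Among the numbers that are known, compound 1 stands at the limit of > 100000 nM in this assay, at which 1 of the 3 values shown sits. No step between any two of these compounds has been worked out; the values of compound 2 and compound 3 simply show where each of them lies.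

The compound that follows is compound 4 `c1ccc(-c2nc3ccn(Cc4ccncc4)cc-3n2)cc1`. It differs from compound 1 in one place: pyridin-4-yl in place of 2-chlorophenyl on a saturated chain carbon bound to an aromatic nitrogen. Among the measured compounds shown here, no measured step is available to set the size of this change in this assay, so an expectation can rest only on where compound 1 stands. Compound 4 is expected to remain near that bound, with a step of a number no higher from compound 1 to compound 4 (the limit leaves the size open) that is expected to lie within the scatter, and a good chance that this assay again reports only a limit for it. The estimate for compound 4 in this assay is 100000 nM, expected to fall between 30000 nM and 300000 nM.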

Compound 4, half-maximal cytotoxic concentration: > 100000 nM
Compound 4 was reported as a limit; the forecaster's own chance of this, stated with the estimate: 50%; the middle value sits exactly at the limit.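

Among the compounds shown here, compound 1 and compound 4 are both reported only as limits in this assay, so no step between them can be read, and the values now stand as follows: the limit of > 100000 nM in this assay, at which 2 of the 4 values shown sit. The compounds shown leave open how far the true values of compound 1 and compound 4 lie from that limit, and whether they differ at all.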